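Hepatocyte tolerance across a sulfonyl-bearing pyrazole series

A few compounds are considered here, and "the series" means these few. Any claim that something is new, unique, unknown or untested is made for them only; others in the source may bear on it.

Working notes on two measured compounds and one that is not yet measured. For the measured compounds named here, compound 1 `FC(F)(F)c1ccc(-c2nn(-c3ccccc3)cc2-c2nc3ccccc3[nH]2)cc1` and compound 2 `Cc1ccc(-c2nn(-c3ccccc3)cc2-c2nc3ccccc3n2S(=O)(=O)c2cc(C)ccc2C)cc1` share a core and differ in several places at once; no single-change step between them is therefore drawn. In an ADME assay on cells (Hepatocyte, Mus musculus) for cytotoxicity, read by MTT assay, with a stated time of 24 h (a lower number here means that less compound is tolerated, a higher number that more compound is tolerated), compound 1 gives 159000 nM. In this assay compound 2 gives 231000 nM, which is within the scatter of the number for compound 1, so the two stand together and neither is called the better tolerated.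

Compound 3 `Cc1ccc(-c2nn(-c3ccccc3)cc2-c2nc3ccccc3n2S(=O)(=O)c2ccc(C(F)(F)F)cc2)cc1` is the next compound to be measured in this assay. Its change from compound 2: 4-(trifluoromethyl)phenyl in place of 2,5-dimethylphenyl on a sulfonyl sulfur. Going by the values given here, no measured pair shows a step of this kind, so nothing here tells its size or direction. The expectation is that the step of a 1.2-fold lower number from compound 2 to compound 3 (0.08 log units; within the scatter) stays within the scatter, and compound 3 is estimated at 190000 nM, with a range from 90000 nM to 400000 nM.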

Compound 3, half-maximal cytotoxic concentration: 89300 nM
Estimate against measurement, compound 3: 2.1-fold (0.33 log units) above, and the stated range ends above it.
By their numbers in this assay, from the lowest: compounds 3, 1 and 2 (each within the scatter of the next, the first and the last beyond it).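

For the compounds shown here, the aryl group on the sulfonyl sulfur is not a silent place in this assay: 4-(trifluoromethyl)phenyl in place of 2,5-dimethylphenyl gives a 2.6-fold lower number from compound 2 to compound 3 (0.41 log units; beyond the scatter), the first single-place step and one beyond the scatter. The step is modest and rests on one pair, so it gives a direction for this exchange alone. No accompanying measurement bears on the result, and the step stands without an explanation.

The pair cannot separate the arrival of the trifluoromethyl group from the loss of the two methyl groups, and a plain phenyl on the sulfonyl sulfur would help to divide the two. Also open, from the compounds shown here alone, is how tolerance responds when that aryl ring carries an amine or a carboxylic acid.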